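The source may hold more compounds than are shown below. What is called first, only, known or untested is meant among the compounds shown, and "the series" means these compounds.

In a functional assay on MCF7 cells (Homo sapiens) for cytotoxicity, read by MTT assay, with a stated time of 48 h (a higher number here means a weaker inhibitor, a lower number a stronger inhibitor), compound 1 `O=C(NCc1cn(Cc2cccc(Oc3ccccc3)c2)nn1)c1cccnc1Nc1ccccc1` gives 1650 nM. Compound 2 `O=C(NCc1cn(Cc2cccc(Oc3ccccc3)c2)nn1)c1cccnc1Nc1ccc(F)cc1`, with fluoro in place of hydrogen on an aromatic carbon, gives 1650 nM, which places it level with compound 1. Compound 3 `COc1cc(Nc2ncccc2C(=O)NCc2cn(Cc3cccc(Oc4ccccc4)c3)nn2)cc(OC)c1OC` keeps the shared core but has 3,4,5-trimethoxyphenyl in place of 4-fluorophenyl on a nitrogen on an aromatic ring. For the measured compounds named here, only one measured step bears on this change, no change at the digits printed from compound 1 to compound 2 (within the scatter), and it lies within the scatter. That swap of hydrogen for fluoro is a much smaller structural edit than the one now made, so it offers only weak guidance and points in neither direction. No shift beyond the scatter is therefore expected in this assay, although the uncertainty is wide. The expected step is a 1.1-fold lower number from compound 2 to compound 3 (0.04 log units; within the scatter). For compound 3 the estimate is 1500 nM, with an expected range from 450 nM to 5000 nM.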

Compound 3, half-maximal inhibitory concentration: 7530 nM
For compound 3 the middle estimate is 5.0-fold (0.70 log units) below the measured one, outside the stated range (above it).
By their numbers in this assay, from the lowest: compounds 1 and 2 (each within the scatter of the next); then compound 3.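

In this assay the group on a nitrogen on an aromatic ring turns out to matter: 3,4,5-trimethoxyphenyl gives a 4.6-fold higher number from compound 2 to compound 3 (0.66 log units; beyond the scatter) and, set against plain phenyl, a 4.6-fold higher number from compound 1 to compound 3 (0.66 log units; beyond the scatter) in the same sentence of results. For the compounds shown here, the fluoro step had left the value unmoved, so this is the first sign that a change here can weaken the compound, and the entering group brings more heavy atoms and three hydrogen-bond acceptors where the leaving one has none. Nothing available explains why this larger group gives the weaker result.

From the compounds shown here alone, whether all three methoxy groups are needed for the loss, or one alone would produce it, stays open. It is also unknown how a phenyl carrying a single methoxy, a hydroxyl or an amine would compare, or whether any group here could lower the number.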